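From 1H-imidazol-1-yl to 2,4-dimethyl-1H-imidazol-1-yl

The source may hold more compounds than are shown below. What is called first, only, known or untested is meant among the compounds shown, and "the series" means these compounds.

Compound 1 `Cc1cn(-c2csc(Nc3ccc(Br)cc3)n2)c(C)n1` gives 400 nM
Compound 2 `Cc1ccc(Nc2nc(-n3cc(C)nc3C)cs2)cc1` gives 200 nM
Compound 3 `COc1ccc(Nc2nc(-n3ccnc3)cs2)cc1` gives > 100000 nM as a limit

These values come from a functional assay on RKO cells (Homo sapiens) for cytotoxicity, read by resazurin assay, with a stated time of 72 h (a higher number here means a weaker inhibitor, a lower number a stronger inhibitor), and the read-out is the half-maximal inhibitory concentration. Compound 3 stands at the limit of > 100000 nM in this assay, at which 1 of the 3 values shown sits, and has no number of its own.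

Compound 4 `COc1ccc(Nc2nc(-n3cc(C)nc3C)cs2)cc1` has not yet been measured. It differs from compound 3 in a single place 2,4-dimethyl-1H-imidazol-1-yl in place of 1H-imidazol-1-yl on an aromatic carbon and so gains the group that compound 1 and compound 2 already carry. For the measured compounds named here, the one measured step among those compounds is a 2.0-fold lower number from compound 1 to compound 2 (0.30 log units; within the scatter) with methyl in place of bromo on an aromatic carbon, and it stays within the scatter. Going by the values given here, no measured step changes the imidazole group directly, and none tests the methoxy group of compound 3 against the other two substituents, so the forecast rests on the values themselves. Compound 4 should resemble compound 1 at 400 nM and compound 2 at 200 nM in this respect. The expected change is an at least 330-fold lower number from compound 3 to compound 4 (2.52 log units; beyond the scatter) and this estimated move toward a lower number lies far beyond the scatter. The estimate for compound 4 in this assay is 300 nM with an expected range from 70 nM to 2000 nM as its two ends.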

Compound 4, half-maximal inhibitory concentration: 250 nM
For compound 4 the middle estimate is 1.2-fold (0.08 log units) above the measured one, within the range that was stated.
By their numbers in this assay, from the lowest: compounds 2, 4 and 1 (each within the scatter of the next). At a limit, above all of these: compound 3.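

In this assay, for the compounds shown here, the step of an at least 400-fold lower number from compound 3 to compound 4 (2.60 log units; beyond the scatter) is the first measured change at this position, an aromatic carbon next to the ring nitrogen, and it shows that 2,4-dimethyl-1H-imidazol-1-yl in place of 1H-imidazol-1-yl goes with a large change in the read-out. The size of this step is only a bound, because compound 3 has a limit of the assay rather than a number of its own: the limit of > 100000 nM in this assay, at which 1 of the 4 values shown sits. With 2,4-dimethyl-1H-imidazol-1-yl in place, the steps of a 1.3-fold higher number from compound 2 to compound 4 (0.10 log units; within the scatter) and a 1.6-fold lower number from compound 1 to compound 4 (0.20 log units; within the scatter) both stay within the scatter, so methoxy, methyl and bromo cannot be told apart here, while the change at the imidazole position stands far beyond it.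

The compounds shown carry either both methyl groups or neither, so it stays open whether the methyl at the 2-position or the one at the 4-position alone would give a value like that of compound 4. As far as these compounds go, it also stays open whether a longer chain such as ethyl, or an amine, would be tolerated at either place on the imidazole ring.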